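Alkyne, alkene and alkane on the carbonyl carbon

The source may hold more compounds than are shown below. What is called first, only, known or untested is meant among the compounds shown, and "the series" means these compounds.

Measured so far:
compound 1 `Cc1ccc(C(CCN(C)C)NC(=O)C#Cc2ccccc2)cc1` — 131%
compound 2 `Cc1ccc(C(CCN(C)C)NC(=O)CCc2ccccc2)cc1` — 73%

Both compounds were run in a functional assay on NIH3T3 cells for agonist activity at Urotensin-2 receptor (Homo sapiens), with a stated time of 5 days; a higher number here means a larger maximal response, a lower number a smaller maximal response. Among the compounds with values here, compound 2 stands at the lower end of the two numbers, and the one measured step, a number 58 percentage points lower from compound 1 to compound 2 (beyond the scatter), is large and beyond the scatter, so compound 1 sits clearly higher on this read-out.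

Compound 3 `Cc1ccc(C(CCN(C)C)NC(=O)/C=C/c2ccccc2)cc1` has not yet been measured. It differs from compound 2 in a single place: 2-phenylethenyl in place of phenethyl on a carbonyl carbon. Within the data shown here, the only measured step that bears on this change is the one in which the fully saturated phenethyl group replaced 2-phenylethynyl on the same carbonyl carbon, and that step was a number 58 percentage points lower from compound 1 to compound 2 (beyond the scatter). Compound 3 carries one double bond outside aromatic rings at this position, which places it structurally between the two measured compounds. The expected step of a number 32 percentage points higher from compound 2 to compound 3 (beyond the scatter) is therefore upward and beyond the scatter, but smaller than the measured step between the alkyne and the alkane. Compound 3 is estimated to reach 105% in this assay, within a range from 80% to 130%.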

Compound 3, largest response reached (reported as efficacy), in percent of the reference or control that the assay uses: 97%
Compound 3: the middle estimate sits 8 percentage points above what was measured; the measured number falls inside the stated range.
By their numbers in this assay, from the lowest: compound 2; then compound 3; then compound 1.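

With 2-phenylethenyl on the carbonyl carbon, this assay gains an intermediate point in the series: a number 24 percentage points higher from compound 2 to compound 3 (beyond the scatter), and a number 34 percentage points lower from compound 1 to compound 3 (beyond the scatter). Both steps are beyond the scatter, so among these three compounds the maximal response rises from phenethyl through 2-phenylethenyl to 2-phenylethynyl, with no compound going against that order. Phenethyl and 2-phenylethenyl match in heavy atoms and in hydrogen-bond donors and acceptors, and the count of double bonds outside aromatic rings is the listed difference between them, yet no measurement available here accounts for the change in response.

Still open, on these data alone, is whether this order survives in other settings, such as the cis form of the 2-phenylethenyl group, a longer chain between the carbonyl carbon and the phenyl ring, or a phenyl ring carrying a carboxylic acid or an amine. The three values also describe maximal response alone, leaving open how the same changes at this carbonyl carbon would appear in any other read-out or on a different core.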